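Moving to 2,4,5-trifluorophenyl: little change expected

The source may hold more compounds than are shown below. What is called first, only, known or untested is meant among the compounds shown, and "the series" means these compounds.

compound 1 `CC(C)[C@H](NC(=O)COc1cccc2ccccc12)C(=O)N[C@@H](CC(=O)O)C(=O)COc1ccc(-c2ccccc2)cc1` gives 38700 nM in the assay below
compound 2 `CC(C)[C@H](NC(=O)COc1cccc2ccccc12)C(=O)N[C@@H](CC(=O)O)C(=O)COc1ccc(F)c(F)c1` gives 16200 nM in the assay below
compound 3 `CC(C)[C@H](NC(=O)COc1cccc2ccccc12)C(=O)N[C@@H](CC(=O)O)C(=O)COc1ccc(F)c(F)c1F` gives 20600 nM in the assay below

All three values come from a functional assay with Homo sapiens as the target (on this read-out higher numbers stand for weaker inhibition and lower numbers for stronger inhibition), and the compounds differ only in the group on an oxygen on a saturated carbon. The numbers do not separate compound 3 from either of the other two, since it lies within the usual scatter of both.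

The next compound is compound 4 `CC(C)[C@H](NC(=O)COc1cccc2ccccc12)C(=O)N[C@@H](CC(=O)O)C(=O)COc1cc(F)c(F)cc1F` with the same atoms joined differently: 2,4,5-trifluorophenyl in place of 2,3,4-trifluorophenyl on an oxygen on a saturated carbon and so 2,4,5-trifluorophenyl stands in place of 2,3,4-trifluorophenyl.

Going by the values given here, no measured step shows this exact change, so the nearest ones must serve. Putting fluoro in place of hydrogen on an aromatic carbon gave a 1.3-fold higher number from compound 2 to compound 3 (0.10 log units; within the scatter) and that is the closest comparison. Much bigger replacements of 4-phenylphenyl also moved the number only modestly, with a 2.4-fold lower number from compound 1 to compound 2 (0.38 log units; beyond the scatter) for 3,4-difluorophenyl and a 1.9-fold lower number from compound 1 to compound 3 (0.27 log units; within the scatter) for 2,3,4-trifluorophenyl.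

Among the compounds with values here, only three compounds support this reading, but a step beyond the scatter is not expected here. The estimated step is a 1.1-fold lower number from compound 3 to compound 4 (0.06 log units; within the scatter) in this assay and its direction is uncertain.

For compound 4 the estimated value is 18000 nM (expected range 8000 nM to 40000 nM).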

Compound 4, half-maximal inhibitory concentration: 16700 nM
For compound 4 the middle estimate is 1.1-fold (0.03 log units) above the measured one; the measured number falls inside the stated range.
By their numbers in this assay, from the lowest: compounds 2, 4, 3 and 1 (each within the scatter of the next, the first and the last beyond it).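

In this assay, moving the fluorines around the ring on this oxygen, from 2,3,4-trifluorophenyl to 2,4,5-trifluorophenyl, gives a 1.2-fold lower number from compound 3 to compound 4 (0.09 log units; within the scatter), and comparison with the 3,4-difluorophenyl group gives a 1.0-fold higher number from compound 2 to compound 4 (0.01 log units; within the scatter). Going by these compounds alone, the earlier compounds showed only the effect of adding a fluoro, so this is the first sign that rearranging the fluorines with the atom count unchanged also leaves the number within the scatter at this position. Replacing 4-phenylphenyl gives a 2.3-fold lower number from compound 1 to compound 4 (0.36 log units; beyond the scatter), which places compound 4 with compound 2 beyond the scatter of compound 1, whereas compound 3 stays within it, and no measurement among these compounds offers an explanation for any of these steps.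

As far as these compounds go, all the groups compared here on this oxygen are aromatic rings of carbon only, so it remains open how a pyridine ring, a methoxy-substituted phenyl or an amine-bearing chain would read in this assay. From the compounds shown here alone, it is also open whether any change at this position can move the number much further, or whether a larger shift would need a change elsewhere on the shared core.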